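The source may report more compounds than this note shows. Statements on the series, on what has been measured and on what is new or still open speak of the compounds shown alone.

In a functional assay on HeLa cells (Homo sapiens) for antiproliferative activity, read by resazurin assay (on this read-out lower numbers stand for stronger inhibition and higher numbers for weaker inhibition), three compounds have been measured:
- Compound 1 `CCSC(=S)SCC(=O)c1ccc(OC)cc1OC` gives 12600 nM
- Compound 2 `CCSC(=S)SCC(=O)c1ccccc1` gives 5010 nM
- Compound 3 `Cc1ccc(C(=O)CSC(=S)SC(C)(C)C)cc1` gives 31600 nM

Compound 3 has the highest number of the three, and its gaps to compound 1 and compound 2 both lie beyond the scatter. Compound 4 `Cc1ccc(C(=O)CSC(=S)SC(C)C)cc1` differs from compound 3 in one place: hydrogen in place of methyl on a saturated chain carbon bound to two saturated chain carbons and a sulfur. Tert-butyl becomes isopropyl, with hydrogen in place of methyl on a saturated chain carbon bound to two saturated chain carbons and a sulfur. Among the measured compounds shown here, no measured pair shows this change alone. With an ethyl chain instead of tert-butyl and without the methyl of compound 3, compound 2 gives 5010 nM, which offers only loose support for a lower number. A small move toward stronger inhibition, possibly within the scatter, is expected, with an estimated step of a 1.8-fold lower number from compound 3 to compound 4 (0.24 log units; within the scatter). For compound 4 the expected value is 18000 nM, with an estimated range of 7000 nM to 40000 nM.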

Compound 4, half-maximal inhibitory concentration: 25100 nM
For compound 4 the middle estimate is 1.4-fold (0.14 log units) below the measured one, within the range that was stated.
By their numbers in this assay, from the lowest: compound 2; then compounds 1, 4 and 3 (each within the scatter of the next, the first and the last beyond it).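

In this assay, among the compounds shown here, this is the first direct reading of the change from (tert-butyl)sulfanyl to isopropylsulfanyl, since no earlier pair isolated it. The step is a 1.3-fold lower number from compound 3 to compound 4 (0.10 log units; within the scatter), so at this position, with the rest of the core held fixed, hydrogen in place of methyl does not move the read-out beyond the scatter. No independent evidence bears on this result.

As far as these compounds go, it remains open whether a longer chain, a benzyl group or an amine in place of the isopropyl would leave the read-out equally unmoved.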